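A few compounds are considered here, and "the series" means these few. Any claim that something is new, unique, unknown or untested is made for them only; others in the source may bear on it.

Working notes on the series, read in a functional assay on KYSE-410 cells (Homo sapiens) for antiproliferative activity, read by MTT assay, with a stated time of 72 h; a lower number here means a stronger inhibitor, a higher number a weaker inhibitor. Compound 1 `O=C(Nc1cccc(F)c1)c1cc(=O)[nH]c2cc(-c3ccc(F)cc3)ccc12` gives 10300 nM. Compound 2 `O=C(Nc1cccc(F)c1)c1cc(=O)[nH]c2cc(-c3ccc(F)nc3)ccc12` gives only a limit, > 20000 nM. Compound 3 `Cc1cc(-c2ccc3c(C(=O)Nc4cccc(F)c4)cc(=O)[nH]c3c2)c(C)cc1F` also gives only a limit, > 20000 nM, so it has no number of its own. Compound 4 `C=Cc1ccc2c(C(=O)Nc3cccc(F)c3)cc(=O)[nH]c2c1` carries vinyl in place of 4-fluoro-2,5-dimethylphenyl on an aromatic carbon. Among the measured compounds shown here, two measured steps bear on this only loosely, since both swap one ring for another: an at least 1.9-fold higher number from compound 1 to compound 2 (0.28 log units; that floor lies within the scatter), and an at least 1.9-fold higher number from compound 1 to compound 3 (0.28 log units; that floor lies within the scatter). For the measured compounds named here, with compound 1 at 10300 nM as the only number, a modest shift to a lower number is expected, and it may not clear the scatter. The estimated step is an at least 1.4-fold lower number from compound 3 to compound 4 (0.15 log units; that floor lies within the scatter). For compound 4 the expected value is 14000 nM, with an estimated range of 6000 nM to 30000 nM.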

Compound 4, half-maximal inhibitory concentration: 13600 nM
Compound 4: the middle estimate sits 1.0-fold (0.01 log units) above what was measured; low and high end bracket the measured number.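

In this assay, vinyl in place of 4-fluorophenyl gives a 1.3-fold higher number from compound 1 to compound 4 (0.12 log units; within the scatter), so a ring on this aromatic carbon is not required for a readable value. Against the other two rings, the steps are an at least 1.4-fold lower number from compound 3 to compound 4 (0.16 log units; that floor lies within the scatter) and an at least 1.4-fold lower number from compound 2 to compound 4 (0.16 log units; that floor lies within the scatter). Both are floors, as compound 2 and compound 3 carry only limits: the limit of > 20000 nM in this assay, at which 2 of the 4 values shown sit.

From the compounds shown here alone, what an ethyl group, a longer chain or an amine would give at this position stays open. The compounds shown also leave open whether any group here can bring a clear gain over compound 1.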